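Dialkylamino size on the shared core of compound 1

This account rests on a few compounds, and the source may have more. Where it says the series, first, only, none or still open, it means among the compounds named here.

Measured: compound 1 `CCCN(CCC)c1ccc(C)c2nc(-c3c(OC)cc(COC)cc3OC)c(C)cc12`, 70 nM; compound 2 `CCCN(CCC)c1ccc(C)c2nc(Oc3c(OC)cc(COC)cc3OC)c(C)cc12`, "not determined" (no result reported).

Among the compounds with values here, in a functional assay on HEK293 cells for antagonist activity at corticotropin-releasing factor receptor 1 (Homo sapiens), read by cAMP accumulation and immunoassay, with a stated time of 30 min (a higher number here means a weaker inhibitor, a lower number a stronger inhibitor), compound 1 gives 70 nM, the only number available; compound 2 gives "not determined" (no result reported), so compound 1 stands alone without a comparison. Compound 3 `COCc1cc(OC)c(-c2nc3c(C)ccc(N(C)C)c3cc2C)c(OC)c1` is still to be measured. It differs from compound 1 in one place: dimethylamino in place of dipropylamino on an aromatic carbon, the shorter amine replacing the longer one on the core. Within the data shown here, no measured step covers this change. The step from compound 1 to compound 3 is expected to be an 8.6-fold higher number from compound 1 to compound 3 (0.93 log units; beyond the scatter), beyond the scatter, toward weaker inhibition. Compound 3 is estimated at 600 nM, within 150 nM to 2500 nM.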

Compound 3, half-maximal inhibitory concentration: > 1000 nM
Compound 3: only a limit was reported; the forecaster's own chance of this, stated with the estimate: 10%; at least 1.6-fold (0.22 log units) between middle value and limit.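

In this assay, the amine on the shared core proves sensitive to change: dimethylamino in place of dipropylamino gives an at least 14-fold higher number from compound 1 to compound 3 (1.15 log units; beyond the scatter). Compound 3 gives > 1000 nM, which is a limit of the assay and not a number. The step therefore sets only a minimum size, and its full size cannot be read: the limit of > 1000 nM in this assay, at which 1 of the 3 values shown sits.

Two amines cannot show whether the change follows chain length. Diethylamino, dibutylamino or a cyclic amine such as pyrrolidine on the same aromatic carbon would bear on that question.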